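Pyridin-4-yl for pyridin-3-yl, a second instance in the series

A few compounds are considered here, and "the series" means these few. Any claim that something is new, unique, unknown or untested is made for them only; others in the source may bear on it.

Compound 1 `O=C(/C=C/c1cn(-c2ccccc2)nc1-c1cccnc1)c1cc[nH]c1` gives 6900 nM in a functional assay on MCF7 cells (Homo sapiens) for inhibition, read by sulforhodamine B assay, with a stated time of 72 h; a higher number here means a weaker inhibitor, a lower number a stronger inhibitor. Compound 3 `O=C(/C=C/c1cn(-c2ccccc2)nc1-c1ccncc1)c1cc[nH]c1` gives 13600 nM in this assay. The change between them is pyridin-4-yl in place of pyridin-3-yl on an aromatic carbon, and its size is a 2.0-fold higher number from compound 1 to compound 3 (0.29 log units; within the scatter).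

Compound 2 `COc1ccc(C(=O)/C=C/c2cn(-c3ccccc3)nc2-c2cccnc2)c(OC)c1OC` gives 1400 nM in this assay; this is the lowest of the three numbers, with compound 1 nearest and compound 3 furthest, both beyond the scatter. The difference between the core of compound 1 and the core of compound 2 is not broken down here, since the two differ in more than one place.

Compound 4 `COc1ccc(C(=O)/C=C/c2cn(-c3ccccc3)nc2-c2ccncc2)c(OC)c1OC` is still to be measured in this assay. It differs from compound 2 by pyridin-4-yl in place of pyridin-3-yl on an aromatic carbon. This is the same kind of change as that from compound 1 to compound 3, not the same: in compound 2 the place is next to the ring atom that bears a large group, whereas in compound 1 it is next to the ring atom that bears a group of 9 heavy atoms. The same change occurs twice among the compounds shown.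

The expectation for compound 4 rests on the step of a 2.0-fold higher number from compound 1 to compound 3 (0.29 log units; within the scatter), which gives no sign that the isomer swap moves the number far. Compound 4 is therefore expected to show a step of a 2.0-fold higher number from compound 2 to compound 4 (0.30 log units; within the scatter) in this assay. The estimate for compound 4 is 2800 nM, expected to lie between 1200 nM and 6500 nM.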

Compound 4, half-maximal inhibitory concentration: 3300 nM
Compound 4: the middle estimate sits 1.2-fold (0.07 log units) below what was measured; the range from low to high includes it.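

In this assay, pyridin-4-yl in place of pyridin-3-yl gives a 2.4-fold higher number from compound 2 to compound 4 (0.37 log units; beyond the scatter), and the two cores return steps of much the same size: the same change on two cores in this assay, a 2.0-fold higher number (0.29 log units; within the scatter) from compound 1 to compound 3 and a 2.4-fold higher number (0.37 log units; beyond the scatter) from compound 2 to compound 4, 1.2-fold (0.08 log units) apart, within the scatter of two such steps

On these two cores, then, the change carries over with no sign that the core alters its size, and the core of compound 2 keeps the same step even though it starts from a lower number than the core of compound 1. For the compounds shown here, only the step on the core of compound 2 lies beyond the scatter, and modestly so, which means the step on the core of compound 1 fixes no direction by itself; two pairs in a single assay also give no rule for other cores and no explanation of the size of the step.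

The compounds shown hold only pyridin-3-yl and pyridin-4-yl at this place on the five-membered ring, so the outcome with pyridin-2-yl or an unsubstituted phenyl there remains open. Also open, going by these compounds, is whether the step keeps its size on a core where the trimethoxyphenyl group of compound 2 gives way to a plain phenyl ring or one bearing an amine or a carboxylic acid.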